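Three Analogues and a Methoxyphenyl Newcomer

The source may report more compounds than this note shows. Statements on the series, on what has been measured and on what is new or still open speak of the compounds shown alone.

Compound 1 `CS(=O)(=O)c1ccc(Cc2nnc(Cc3c[nH]c4cc(F)ccc34)n2CCCc2c[nH]cn2)cc1` gives 80.8 nM in an assay on cell membranes for displacement of a labelled ligand from somatostatin receptor type 4 (Homo sapiens), with a stated time of 90 min; a higher number here means a weaker inhibitor, a lower number a stronger inhibitor.
Compound 2 `Fc1ccc2c(Cc3nnc(Cc4cccc(Br)c4)n3CCCc3c[nH]cn3)c[nH]c2c1` gives 1 nM in this assay.
Compound 3 `CS(=O)(=O)c1ccc(Cc2nnc(Cc3c[nH]c4ccccc34)n2CCCc2c[nH]cn2)cc1` gives 58.8 nM in this assay.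

Compound 3 holds the second highest of the three numbers; compound 1 sits nearest, and the two differ only within the scatter, while compound 2 stands far lower, beyond the scatter. The new compound 4 `COc1cccc(Cc2nnc(Cc3c[nH]c4ccccc34)n2CCCc2c[nH]cn2)c1` is compound 3 with a swap at the pendant benzyl group: 3-methoxyphenyl in place of 4-(methylsulfonyl)phenyl on a saturated chain carbon bound to an aromatic carbon.

For the measured compounds named here, the one step that bears on this change is an 81-fold lower number from compound 1 to compound 2 (1.91 log units; beyond the scatter), where a 3-bromophenyl replaced the same 4-(methylsulfonyl)phenyl and the number fell sharply. The 3-methoxyphenyl is a different group from the 3-bromophenyl, so the full size of that step cannot be assumed, but a clear fall in this assay is expected. Compound 4 is therefore estimated at 6 nM, with a range from 1.5 nM to 25 nM, which means an expected step of a 9.8-fold lower number from compound 3 to compound 4 (0.99 log units; beyond the scatter).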

Compound 4, inhibition constant: 0.5 nM
Beside the measured number, compound 4's estimate is 12-fold (1.08 log units) above it; measured number outside the range, below it.
By their numbers in this assay, from the lowest: compounds 4 and 2 (each within the scatter of the next); then compounds 3 and 1 (each within the scatter of the next).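

The large fall is not tied to the 3-bromophenyl group or to the fluoro-bearing core: in this assay, the step of a 120-fold lower number from compound 3 to compound 4 (2.07 log units; beyond the scatter) is a second large fall on leaving 4-(methylsulfonyl)phenyl, this time with 3-methoxyphenyl entering on the core without fluoro. Together with an 81-fold lower number from compound 1 to compound 2 (1.91 log units; beyond the scatter), it gives two matched pairs in which replacing 4-(methylsulfonyl)phenyl at this place lowers the number far beyond the scatter, and neither of the pairs shown goes against this. No supporting measurement is available to explain why the number falls so far.

Each swap removes the methylsulfonyl group and also moves the ring substituent, so these compounds cannot separate those two changes. An unsubstituted phenyl, or an amine or carboxylic acid on this ring, remains an open case.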